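Tert-butyl for benzyl on the ring nitrogen of compound 1

The compounds below may be only part of what the source reports. "The series", "measured", "known", "first", "only" and "open" are said of these compounds alone.

Compound 1 `Cc1cn([C@@H]2C[C@H](c3ccccc3)N(Cc3ccccc3)O2)c(=O)[nH]c1=O` — 55200 nM
Compound 2 `CN1O[C@@H](n2ccc(N)nc2=O)C[C@H]1c1ccccc1` — > 100000 nM, a limit of the assay
Compound 3 `CN1O[C@@H](n2ccc(N)nc2=O)C[C@@H]1c1ccccc1` — > 100000 nM, a limit of the assay

Within the data shown here, in a functional assay on LCL cells (Homo sapiens) for cytotoxicity, read by MTT assay, with a stated time of 72 h (on this read-out higher numbers stand for weaker inhibition and lower numbers for stronger inhibition), compound 1 is the only compound for which a number is given. Compound 2 reaches only a limit of the assay. Compound 3 likewise reaches only a limit. The step from compound 2 to compound 3 is a step that the two limits leave unreadable from compound 2 to compound 3, and its size cannot be read because of the limit of > 100000 nM in this assay, at which 2 of the 3 values shown sit; the two compounds are related only through (the fact that compounds 2 and 3 differ only in the configuration as drawn).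

Compound 4 `Cc1cn([C@@H]2C[C@H](c3ccccc3)N(C(C)(C)C)O2)c(=O)[nH]c1=O` arises from compound 1 by tert-butyl in place of benzyl on an amine nitrogen in a ring. Among the measured compounds shown here, no measured step touches the group on this ring nitrogen: the pair of compounds 2 and 3 differs elsewhere and, being two limits, shows nothing about size. Without a step that bears on the change, the expectation for compound 4 in this assay is a step of a 1.0-fold lower number from compound 1 to compound 4 (0.00 log units; within the scatter) from compound 1, that is, none beyond the scatter. Compound 4 is therefore estimated at 55000 nM, with a range from 20000 nM to 150000 nM.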

Compound 4, half-maximal inhibitory concentration: 87100 nM
Compound 4: the middle estimate sits 1.6-fold (0.20 log units) below what was measured; the range from low to high includes it.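

In this assay the group on the ring nitrogen now has a readable step, a 1.6-fold higher number from compound 1 to compound 4 (0.20 log units; within the scatter), which the two limits of the earlier pair could not provide. Here the six-membered aromatic ring of benzyl leaves and tert-butyl, which has no ring, enters, yet the reading stays within the scatter, so in this pair, on the shared core, the aromatic ring of benzyl is not needed for the cytotoxicity seen. No measurement given here accounts for why the two groups read alike.

Benzyl and tert-butyl are only two groups at this nitrogen, so it remains open whether a carboxylic acid, an amine or a longer chain there would give a step beyond the scatter. As far as these compounds go, it is also open whether configuration matters on a compound with a measurable value, since compounds 2 and 3 both stand at a limit of the assay and the step between them cannot be read.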